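The compounds below may be only part of what the source reports. "The series", "measured", "known", "first", "only" and "open" are said of these compounds alone.

Of the compounds shown here, two of the same shared core have been tested so far. Compound 1 `O=C(Nc1ccc(Oc2ccnc3[nH]ccc23)cc1)c1cc2cccnc2n(-c2ccc(F)c(Cl)c2)c1=O` was run in a functional assay on A549 cells (Homo sapiens) for antiproliferative activity, read by MTT assay, with a stated time of 72 h (on this read-out higher numbers stand for weaker inhibition and lower numbers for stronger inhibition), and compound 1 gives 680 nM. Compound 2 `Cn1ccc2c(Oc3ccc(NC(=O)c4cc5cccnc5n(-c5ccc(Br)cc5)c4=O)cc3)ccnc21` carries a 4-bromophenyl on an aromatic nitrogen and a methyl on the other ring; in this assay compound 2 gives 680 nM, level with compound 1 at the digits shown, so no change can be read between the two. The next compound, compound 3 `Cn1ccc2c(Oc3ccc(NC(=O)c4cc5cccnc5n(-c5ccc(F)c(Cl)c5)c4=O)cc3)ccnc21`, takes the aryl group of compound 1 and the methyl of compound 2. The change from compound 2 is 3-chloro-4-fluorophenyl in place of 4-bromophenyl on an aromatic nitrogen. Within the data shown here, no direct step between measured compounds covers this swap, so the expected move from compound 2 to compound 3 is no change at the digits printed from compound 2 to compound 3 (within the scatter), that is, none beyond the scatter, because compound 1 with the same 3-chloro-4-fluorophenyl gives 680 nM. Compound 3 is therefore estimated at 680 nM, with a range from 340 nM to 1400 nM.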

Compound 3, half-maximal inhibitory concentration: 820 nM
Compound 3: middle estimate off by 1.2-fold (0.08 log units), on the low side; the range from low to high includes it.
By their numbers in this assay, from the lowest: compounds 1, 2 and 3 (each within the scatter of the next).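

In this assay, 3-chloro-4-fluorophenyl in place of 4-bromophenyl on the aromatic nitrogen gives a small step (a 1.2-fold higher number from compound 2 to compound 3 (0.08 log units; within the scatter)), so these two halogen-bearing aryl groups cannot be told apart here when the methyl is present. Among these compounds, the result also gives the first direct reading of methyl in place of hydrogen on an aromatic nitrogen with the aryl group held fixed, and that step (a 1.2-fold higher number from compound 1 to compound 3 (0.08 log units; within the scatter)) also stays within the scatter. Nothing measured here bears on why these two changes leave the number within the scatter.

All three aryl groups shown carry only halogens, and the only other group shown on the second nitrogen is a methyl. Going by these compounds, it remains open whether an aryl group bearing an amine or a carboxylic acid, or a longer chain such as propyl in place of the methyl, would shift the number beyond the scatter.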